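Sulfonamide in place of cinnamamide on the D(3) core

This account rests on a few compounds, and the source may have more. Where it says the series, first, only, none or still open, it means among the compounds named here.

Measured compounds:
Compound 1 `CCCN(CC[C@H]1CC[C@H](NC(=O)/C=C/c2ccc(F)cc2)CC1)[C@H]1CCc2nc(N)sc2C1`: 1 nM
Compound 2 `CCCN(CC[C@H]1CC[C@H](NC(=O)c2cccc(-n3cncn3)c2)CC1)[C@H]1CCc2nc(N)sc2C1`: 3 nM
Compound 3 `CCCN(CC[C@H]1CC[C@H](NC(=O)c2ccc(-n3cccn3)cc2)CC1)[C@H]1CCc2nc(N)sc2C1`: 3 nM

All three share one core and differ only in the acyl group on the amide nitrogen. In an assay on brain for displacement of a labelled ligand from D(3) dopamine receptor (Rattus norvegicus) (a lower number here means a stronger inhibitor, a higher number a weaker inhibitor), compound 1 gives 1 nM, the lowest of the three numbers, and both of its steps to the others lie beyond the scatter, so compound 1 is the strongest binder of the measured set. Replacing its acyl group by an aryl carbonyl gave a 3.0-fold higher number from compound 1 to compound 2 (0.48 log units; beyond the scatter) and a 3.0-fold higher number from compound 1 to compound 3 (0.48 log units; beyond the scatter), while the two aryl carbonyls showed no change at the digits printed from compound 2 to compound 3 (within the scatter).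

Compound 4 `CCCN(CC[C@H]1CC[C@H](NS(=O)(=O)c2ccccc2)CC1)[C@H]1CCc2nc(N)sc2C1` is not yet measured. It differs from compound 1 by phenylsulfonyl in place of (2-(4-fluorophenyl)ethenyl)carbonyl on an amine nitrogen. Among the measured compounds shown here, no measured step shows this change: the two known steps keep a carbonyl and only swap the aryl part, each with a modest loss. The step to compound 4 removes the carbonyl altogether and inserts a sulfonyl, a larger change than either measured one, so a loss in this assay at least as large as those steps is expected, with wide uncertainty. The expected step is a 30-fold higher number from compound 1 to compound 4 (1.48 log units; beyond the scatter). For compound 4 the estimate in this assay is 30 nM, within 5 nM to 200 nM.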

Compound 4, inhibition constant: 0.79 nM
Compound 4: the middle estimate sits 38-fold (1.58 log units) above what was measured; the measured number lies below the stated range.
By their numbers in this assay, from the lowest: compounds 4 and 1 (each within the scatter of the next); then compounds 2 and 3 (each within the scatter of the next).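

On the amine nitrogen of the shared core, the carbonyl turns out not to be needed to keep binding in this assay: phenylsulfonyl in place of (2-(4-fluorophenyl)ethenyl)carbonyl gives a 1.3-fold lower number from compound 1 to compound 4 (0.10 log units; within the scatter). The earlier compounds shown here all kept a carbonyl on this nitrogen and changed only the group attached to it, so they could not show that a sulfonyl can stand in its place, or that a plain phenyl group without fluorine and without the ethenyl link can carry the number at this level. Nothing given here explains why this exchange leaves the number within the scatter.

The compounds shown leave open whether a fluorine or a methoxy group on the phenyl ring of the phenylsulfonyl group would move the number, and whether a methyl group or a longer alkyl chain could replace that phenyl ring on the sulfonyl. They also leave open how a urea or a carbamate on the same nitrogen would compare with the sulfonyl and the carbonyl.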